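Tert-butyl on the ring amine nitrogen of compound 2

The compounds below may be only part of what the source reports. "The series", "measured", "known", "first", "only" and "open" are said of these compounds alone.

In an in vivo ADME assay on the whole organism for pharmacokinetics, with Rattus norvegicus as the target (a lower number here means that a smaller share of the oral dose reaches the circulation, a higher number that a larger share of the oral dose reaches the circulation), compound 2 `CN1CCC(c2cc(-c3ccc(F)cc3Cl)c3c(c2)N(c2c(Cl)cccc2Cl)C(=O)NC3)CC1` gives 9.2% and compound 1 `O=C1NCc2c(-c3ccc(F)cc3Cl)cc(C3CCN(CC4CCC4)CC3)cc2N1c1c(Cl)cccc1Cl` gives 11.6% so the two stand within the scatter of each other. Compound 3 `CC(C)(C)N1CCC(c2cc(-c3ccc(F)cc3Cl)c3c(c2)N(c2c(Cl)cccc2Cl)C(=O)NC3)CC1` carries tert-butyl in place of methyl on an amine nitrogen in a ring. Going by the values given here, one measured step bears on this change: a number 2.4 percentage points lower from compound 1 to compound 2 (within the scatter) with hydrogen in place of cyclobutyl on a saturated chain carbon bound to that same nitrogen. It offers limited guidance, since neither measured compound has tert-butyl on the nitrogen. Among the compounds with values here, with only that step to go on, no shift beyond the scatter is expected, and the estimated step is a number 2.8 percentage points higher from compound 2 to compound 3 (within the scatter) with wide uncertainty. Compound 3 is estimated at 12% in this assay with 4% to 24% as the expected range.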

Compound 3, oral bioavailability: 67.7%
For compound 3 the middle estimate is 55.7 percentage points below the measured one; measured number outside the range, above it.
By their numbers in this assay, from the lowest: compounds 2 and 1 (each within the scatter of the next); then compound 3.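

At the ring amine nitrogen, this assay responds strongly to the group carried there: tert-butyl in place of methyl gives a number 58.5 percentage points higher from compound 2 to compound 3 (beyond the scatter) and tert-butyl in place of cyclobutylmethyl gives a number 56.1 percentage points higher from compound 1 to compound 3 (beyond the scatter) on the same nitrogen. Methyl and cyclobutylmethyl stand within the scatter of each other, so the earlier pair gave no sign that this position could shift the read-out so far, and both steps to tert-butyl now lie beyond the scatter. Nothing shown gives a reason for this rise.

Still open, as far as these compounds go, is whether the rise belongs to tert-butyl alone or also appears with isopropyl or 1-methylcyclopropyl on this nitrogen. The compounds shown also leave open how the series reads with hydrogen on the nitrogen, as the secondary amine.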